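Series notes on cell tolerance ahead of compound 4

A few compounds are considered here, and "the series" means these few. Any claim that something is new, unique, unknown or untested is made for them only; others in the source may bear on it.

Three compounds have so far been run in an ADME assay on HEK-293T cells (Homo sapiens) for cytotoxicity, read by CCK-8 assay, with a stated time of 24 h; a higher number here means that more compound is tolerated, a lower number that less compound is tolerated. Compound 1 `COc1ccccc1CNC(=O)CSc1c[nH]c2ccc(Br)cc12` carries a 2-methoxyphenyl on a saturated chain carbon bound to an amide-type nitrogen. In this assay compound 1 gives > 100000 nM, which is a limit of the assay and not a number. Compound 3 `COc1ccccc1CNC(=O)CSc1cn(C)c2ccccc12` carries the same 2-methoxyphenyl on another core; the difference between the core of compound 1 and the core of compound 3 is not broken down here. In this assay compound 3 gives > 100000 nM, again only a limit. Compound 2 `Cn1cc(SCC(=O)NCc2ccc(Cl)c(Cl)c2)c2ccccc21` differs from compound 3 by 3,4-dichlorophenyl in place of 2-methoxyphenyl on a saturated chain carbon bound to an amide-type nitrogen. In this assay compound 2 gives > 100000 nM, also a limit. The step that the two limits leave unreadable from compound 3 to compound 2 cannot be sized, because the limit of > 100000 nM in this assay, at which 3 of the 3 values shown sit, leaves no readable number on either side.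

Compound 4 `O=C(CSc1c[nH]c2ccc(Br)cc12)NCc1ccc(Cl)c(Cl)c1` is not yet measured. It differs from compound 1 by 3,4-dichlorophenyl in place of 2-methoxyphenyl on a saturated chain carbon bound to an amide-type nitrogen, the same change as from compound 3 to compound 2, made in the same place. The step from compound 1 to compound 4 is expected to be a step that the limit leaves unreadable from compound 1 to compound 4, an expectation that rests on the limit of > 100000 nM in this assay, at which 3 of the 3 values shown sit, holding for every measured compound, so that no shift has yet been seen anywhere in the series. For compound 4 in this assay the estimate is 120000 nM, with a range from 50000 nM to 300000 nM, and the most likely outcome is that only a limit is reported again.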

Compound 4, half-maximal cytotoxic concentration: > 100000 nM
Compound 4: a limit, no number; the forecaster's own chance of this, stated with the estimate: 85%; the middle value is on the limit's open side.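

No step can be read from compound 1 to compound 4, or from any other pair in the series, because every result is a limit of the assay and not a number: the limit of > 100000 nM in this assay, at which 4 of the 4 values shown sit.

The compounds shown leave open where tolerance in this assay actually ends for any of them, and whether 3,4-dichlorophenyl in place of 2-methoxyphenyl shifts it at all.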